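Swapping phenoxy for 4-methylphenyl: compound 2 to compound 3

This account rests on a few compounds, and the source may have more. Where it says the series, first, only, none or still open, it means among the compounds named here.

Two compounds of the series carry numbers in an assay for inhibition of Amine oxidase [flavin-containing] B (Homo sapiens), read by fluorescence and spectrophotometry, using microsomes, with stated times of 30 min and 20 min; on this read-out lower numbers stand for stronger inhibition and higher numbers for weaker inhibition. Compound 1 `Cc1nn(Cc2nc(-c3cccc(C4=NCCN4)c3)no2)c(=O)c2ccccc12` gives 23900 nM. Compound 2 `c1ccc(OCc2noc(-c3ccc(C4=NCCN4)cc3)n2)cc1` gives 9980 nM, the lowest of the two numbers, with compound 1 standing beyond the scatter above it. Compound 3 `Cc1ccc(Cc2noc(-c3ccc(C4=NCCN4)cc3)n2)cc1` has not been measured. Its difference from compound 2 is 4-methylphenyl in place of phenoxy on a saturated chain carbon bound to an aromatic carbon; the same change cut one bond further out reads phenoxymethyl to 4-methylbenzyl. Going by the values given here, no measured pair in the set shows this change, so its size cannot be read from the data. The two groups match in heavy-atom count and ring type and differ only in the one hydrogen-bond acceptor counted, which gives no basis to expect a shift beyond the scatter in either direction. Compound 3 is therefore estimated at 12000 nM, with a range from 4000 nM to 36000 nM. The expected step of a 1.2-fold higher number from compound 2 to compound 3 (0.08 log units; within the scatter) is small and without a firm direction.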

Compound 3, half-maximal inhibitory concentration: 3640 nM
For compound 3 the middle estimate is 3.3-fold (0.52 log units) above the measured one; the whole stated range lies above it.
By their numbers in this assay, from the lowest: compound 3; then compound 2; then compound 1.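

In this assay, going by these compounds alone, 4-methylphenyl in place of phenoxy on a saturated chain carbon bound to an aromatic carbon gives a 2.7-fold lower number from compound 2 to compound 3 (0.44 log units; beyond the scatter), the first readable step and a modest one. This position therefore responds to the group it carries, and inhibition is retained without the oxygen of phenoxy and its counted hydrogen-bond acceptor. Nothing available explains the direction or size of the step.

The change removes the oxygen and adds the methyl together, so the compounds shown cannot divide the step between those two edits. An unsubstituted benzyl group would separate them, while a 4-methoxybenzyl group would show how an oxygen placed further out on the ring compares with the methyl of compound 3.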